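Swapping the aryl ether on compound 1

The compounds below may be only part of what the source reports. "The series", "measured", "known", "first", "only" and "open" are said of these compounds alone.

Compound 1 `Nc1cc(N)c2nc(-c3ccccc3)c(Oc3ccc(Cl)c(Cl)c3)nc2c1` was tested in a functional assay on OVCAR-8 cells (Homo sapiens) for inhibition, read by sulforhodamine B assay, with a stated time of 48 h (a lower number here means a stronger inhibitor of growth, a higher number a weaker inhibitor of growth), and gave 89100 nM. Among the two compounds measured here, compound 1 has the highest number, meaning the weakest growth inhibition. The nearest neighbour is compound 2 `COc1ccc(CNc2nc3cc(N)cc(N)c3nc2-c2ccccc2)cc1`, which in this assay gives 39800 nM, a number lower than that of compound 1 by a margin beyond the usual scatter. No single-point change connects these two compounds, so only their two values can be compared. Compound 3 `Nc1cc(N)c2nc(-c3ccccc3)c(Oc3ccc(F)cc3)nc2c1` has not yet been measured. It differs from compound 1 in one place: 4-fluorophenyl in place of 3,4-dichlorophenyl on an oxygen on an aromatic ring. Among the measured compounds shown here, nothing measured here shows how such a change on the aryl ether affects this assay, so no step is known. The expected change from compound 1 to compound 3 is a 1.1-fold higher number from compound 1 to compound 3 (0.05 log units; within the scatter), a small step, likely not beyond the scatter. Compound 3 is therefore estimated at 100000 nM, within a range of 40000 nM to 250000 nM.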

Compound 3, concentration for total growth inhibition: 47900 nM
Estimate against measurement, compound 3: 2.1-fold (0.32 log units) above; low and high end bracket the measured number.
By their numbers in this assay, from the lowest: compounds 2, 3 and 1 (each within the scatter of the next, the first and the last beyond it).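

Among the compounds shown here, this is the first measured step at this position. In this assay, 4-fluorophenyl in place of 3,4-dichlorophenyl on the oxygen gives a 1.9-fold lower number from compound 1 to compound 3 (0.27 log units; within the scatter), so this assay does not separate the two aryl ethers, even though two chlorine atoms give way to one fluorine and the six-membered aromatic ring of carbon stays. Nothing here explains this result.

On these data alone, with the two halogens and their places altered in a single step, the part played by each one stays unknown. As far as these compounds go, it is also open whether a group of another kind on this oxygen, such as a longer carbon chain or a phenyl ring carrying a carboxylic acid or an amine, would shift the number beyond the scatter.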